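This account rests on a few compounds, and the source may have more. Where it says the series, first, only, none or still open, it means among the compounds named here.

Compound 3 `O=C1C(=O)N(CN(c2ccccc2)c2ccccc2)c2cccc(Br)c21` and compound 1 `O=C1C(=O)N(CN(c2ccccc2)c2ccccc2)c2ccccc21` share one core, and compound 1 carries a hydrogen where compound 3 carries bromo (hydrogen in place of bromo on an aromatic carbon). In a functional assay on MDA-MB-468 cells (Homo sapiens) for cytotoxicity, read by sulforhodamine B assay, with a stated time of 48 h (a higher number here means a weaker inhibitor of growth, a lower number a stronger inhibitor of growth), compound 3 gives 63300 nM, while compound 1 gives 21500 nM, a step described as a 2.9-fold lower number from compound 3 to compound 1 (0.47 log units; beyond the scatter). Compound 2 `Cc1ccc2nc(/N=C3\C(=O)N(CN(C)C)c4cccc(Br)c43)sc2c1` is built on another core; how the core of compound 2 and the core of compound 3 differ is not broken down here. In this assay compound 2 gives 27400 nM, which lies within the usual scatter of the value of compound 1. Compound 4 `Cc1ccc2nc(/N=C3\C(=O)N(CN(C)C)c4ccccc43)sc2c1` stands to compound 2 exactly as compound 1 stands to compound 3 (hydrogen in place of bromo on an aromatic carbon); this same change occurs twice among these four compounds. Because the measured step of a 2.9-fold lower number from compound 3 to compound 1 (0.47 log units; beyond the scatter) was only modest, compound 4 is expected to show a step of a 2.3-fold lower number from compound 2 to compound 4 (0.36 log units; beyond the scatter). Compound 4 is therefore estimated at 12000 nM, with a likely range from 5000 nM to 30000 nM.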

Compound 4, concentration for 50% growth inhibition: 35500 nM
Estimate against measurement, compound 4: 3.0-fold (0.47 log units) below, outside the stated range (above it).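

In this assay hydrogen in place of bromo on the core of compound 2 gives a 1.3-fold higher number from compound 2 to compound 4 (0.11 log units; within the scatter) and so stays within the scatter on this core. Set beside the earlier step, the same change does not carry over from one core to the other at the same size: the same change on two cores in this assay, a 2.9-fold lower number (0.47 log units; beyond the scatter) from compound 3 to compound 1 and a 1.3-fold higher number (0.11 log units; within the scatter) from compound 2 to compound 4, 3.8-fold (0.58 log units) apart, beyond the scatter of two such steps. With only these two pairs, this does not show which difference between the cores goes with the gap, nor how the change would behave on a further core.

Both pairs hold only bromo or hydrogen at this one place. From the compounds shown here alone, whether chloro, a methoxy group or an amine there would also differ between the two cores remains open.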